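Aryl substituent swap on a T-type calcium channel blocker series

This account rests on a few compounds, and the source may have more. Where it says the series, first, only, none or still open, it means among the compounds named here.

Compound 1 `CCCc1nc(-c2ccccc2)c(CNCCCN2CCN(c3ccc(F)cc3)CC2)o1`: 3210 nM
Compound 2 `CCCc1nc(-c2ccccc2)c(CNCCCN2CCN(c3ccc(C)cc3)CC2)o1`: 130000 nM
Compound 3 `CCCc1nc(-c2ccccc2)c(CNCCCN2CCN(c3cccc(C)c3)CC2)o1`: 1190 nM

Three compounds share a common core and differ only in the aryl group on the amine nitrogen in the ring. In an assay on HEK293 cells for inhibition of Voltage-dependent T-type calcium channel subunit alpha-1G (Homo sapiens), read by patch clamp (a lower number here means a stronger inhibitor, a higher number a weaker inhibitor), compound 3 gives the lowest number of the three; the nearest is compound 1, and the step from compound 1 to compound 3 is a 2.7-fold lower number from compound 1 to compound 3 (0.43 log units; beyond the scatter), while the step from compound 2 to compound 3 is a 110-fold lower number from compound 2 to compound 3 (2.04 log units; beyond the scatter). The step from compound 1 to compound 2 was a 40-fold higher number from compound 1 to compound 2 (1.61 log units; beyond the scatter).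

Compound 4 `CCCc1nc(-c2ccccc2)c(CNCCCN2CCN(c3ccccc3F)CC2)o1` carries the change (2-fluorophenyl in place of 3-methylphenyl on an amine nitrogen in a ring). Within the data shown here, no measured step bears directly on this change: the two fluoro-bearing compounds differ in where the fluoro sits, and no measured compound carries a group at that place. What the numbers show is that a fluoro on the aryl ring gave compound 1 a number not far from compound 3, whereas a methyl at a different place gave compound 2 a far higher one. On that basis the step from compound 3 to compound 4 in this assay is expected to be a 2.5-fold higher number from compound 3 to compound 4 (0.40 log units; beyond the scatter), a modest rise, with wide uncertainty. Compound 4 is therefore estimated at 3000 nM, within a range of 600 nM to 15000 nM.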

Compound 4, half-maximal inhibitory concentration: 16100 nM
For compound 4 the middle estimate is 5.4-fold (0.73 log units) below the measured one, and the stated range ends below it.
By their numbers in this assay, from the lowest: compound 3; then compound 1; then compound 4; then compound 2.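

The fluoro group on the aryl ring does not carry a fixed effect at this ring nitrogen: moving it from the 4-fluorophenyl to the 2-fluorophenyl arrangement gives a 5.0-fold higher number from compound 1 to compound 4 (0.70 log units; beyond the scatter) in this assay, so the placement of fluoro matters here, as the placement of methyl already did. The change from 3-methylphenyl is larger still, at a 14-fold higher number from compound 3 to compound 4 (1.13 log units; beyond the scatter), whereas the change from 4-methylphenyl runs the other way, at an 8.1-fold lower number from compound 2 to compound 4 (0.91 log units; beyond the scatter), which places the 2-fluorophenyl group between the two methylphenyl groups rather than near the better of them. Nothing available explains why these aryl groups differ as they do.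

As far as these compounds go, because group and placement both vary across these four compounds, it remains open how a 3-fluorophenyl or a 2-methylphenyl group would compare, which would separate the effect of placement from that of the group itself. Plain phenyl, a methoxyphenyl or a chlorophenyl on the same nitrogen would also show whether 3-methylphenyl stands out in this series or whether other groups give lower numbers in this assay on the shared core.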